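Removing a Methyl from a Chalcone: Expected Cytotoxicity

The source may report more compounds than this note shows. Statements on the series, on what has been measured and on what is new or still open speak of the compounds shown alone.

Measured so far:
compound 1, `COc1cc(OC)c(C(=O)/C=C/c2cccc(Cl)c2)c(O)c1CC=C(C)C`: 59500 nM
compound 2, `COc1cc(OC)c(C(=O)/C=C/c2cccc(N3CCNCC3)c2)c(O)c1C`: 98700 nM

In an ADME assay on MCF7-DOX cells (Homo sapiens) for cytotoxicity, read by MTT assay, with a stated time of 48 h (on this read-out lower numbers stand for stronger inhibition and higher numbers for weaker inhibition), compound 2 gives 98700 nM, the highest of the two numbers, yet its gap to compound 1 lies within the scatter of this assay. Compound 3 `COc1cc(O)c(C(=O)/C=C/c2cccc(N3CCNCC3)c2)c(OC)c1` is not yet measured. It differs from compound 2 by hydrogen in place of methyl on an aromatic carbon. For the measured compounds named here, with no steps between measured compounds available, the change is expected to leave the read-out about where compound 2 stands, and the step of a 1.0-fold higher number from compound 2 to compound 3 (0.01 log units; within the scatter) is estimated to stay within the scatter. Compound 3 is therefore expected to give 100000 nM, within 40000 nM to 250000 nM.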

Compound 3, half-maximal inhibitory concentration: 99200 nM
Compound 3: the middle estimate sits 1.0-fold (0.00 log units) above what was measured, within the range that was stated.
By their numbers in this assay, from the lowest: compounds 1, 2 and 3 (each within the scatter of the next).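

In this assay, putting hydrogen in place of methyl on this aromatic carbon gives a 1.0-fold higher number from compound 2 to compound 3 (0.00 log units; within the scatter), so the two compounds cannot be told apart. For these two compounds, then, this methyl makes no measurable difference to the read-out. Nothing measured here explains this result.

A single swap between two small substituents says little about this position as a whole. Going by these compounds, whether a carboxylic acid or a nitrile on the same carbon would shift the number beyond the scatter remains open.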